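The source may hold more compounds than are shown below. What is called first, only, known or untested is meant among the compounds shown, and "the series" means these compounds.

In a functional assay on COLO 205 cells (Homo sapiens) for cytotoxicity, read by MTT assay, with a stated time of 48 h (a lower number here means a stronger inhibitor, a higher number a weaker inhibitor), compound 1 `Fc1cccc(-c2nc(Nc3ccccc3F)c3cc(F)ccc3n2)c1` gives > 50000 nM, a value that is a limit of the assay rather than a number. Within the data shown here, compound 2 `Fc1cccc(-c2nc(Nc3ccc(Br)cc3)c3cc(F)ccc3n2)c1` is the only other compound measured here, and in this assay compound 2 also gives > 50000 nM, again a limit. Among the measured compounds shown here, the change between them, 4-bromophenyl in place of 2-fluorophenyl on a nitrogen on an aromatic ring, therefore yields a step that the two limits leave unreadable from compound 1 to compound 2, and the only evidence so far is the limit of > 50000 nM in this assay, at which 2 of the 2 values shown sit.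

Compound 3 `Nc1ccc(Nc2nc(-c3cccc(F)c3)nc3ccc(F)cc23)cc1` differs from compound 1 by 4-aminophenyl in place of 2-fluorophenyl on a nitrogen on an aromatic ring. For the measured compounds named here, the single measured step bears on this position but has no readable size, so no particular direction or size of step in this assay can be predicted from it. Compound 3 is estimated at 50000 nM, between 10000 nM and 100000 nM. That estimate means an expected step of a number no higher from compound 1 to compound 3 (the limit leaves the size open), most likely ending again at the limit.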

Compound 3, half-maximal inhibitory concentration: > 50000 nM
Compound 3: only a limit was reported; the forecaster's own chance of this, stated with the estimate: 65%; the middle value lies on the limit itself.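

In this assay compound 3 gives > 50000 nM, again a limit and not a number. Among these compounds, no step among compound 1, compound 2 and compound 3 can be read. The compounds shown leave open how much any of these changes shifts the value, because all of them share one result: the limit of > 50000 nM in this assay, at which 3 of the 3 values shown sit.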